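Removing a methyl from compound 2: working notes

The compounds below may be only part of what the source reports. "The series", "measured", "known", "first", "only" and "open" are said of these compounds alone.

Measured so far:
compound 1, `CN(CC1CCN(CCCc2c[nH]c3ccc(-n4cnnc4)cc23)CC1)C(=O)Nc1ccccc1`, 5.9 nM
compound 2, `CC(=O)Nc1ccc([C@@H](C)NCC2CCN(CCCc3c[nH]c4ccc(-n5cnnc5)cc34)CC2)cc1`, 1.5 nM

Both compounds were run in an assay on CHO cells for displacement of a labelled ligand from 5-hydroxytryptamine receptor 1D (Homo sapiens); a higher number here means a weaker inhibitor, a lower number a stronger inhibitor. Compound 1 gives 5.9 nM, and compound 2 gives 1.5 nM. Compound 2 therefore holds the lower of the two numbers, and its gap to compound 1 lies beyond the usual scatter. Within the data shown here, the two structures differ in more than one place, so no single-point step connects them and nothing finer than this comparison can be read from the pair.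

Compound 3, `CC(=O)Nc1ccc(CNCC2CCN(CCCc3c[nH]c4ccc(-n5cnnc5)cc34)CC2)cc1`, is the next candidate for this assay. It differs from compound 2 in one place only: hydrogen in place of methyl on a saturated chain carbon bound to an amine nitrogen and an aromatic carbon. The shared core and the acetamidophenyl arm stay as they are. Among the measured compounds shown here, no measured pair in the set shows the effect of such a removal, so the expectation rests on the smallness of the change: a single methyl leaves and nothing with new functionality enters. The expected step is a 1.7-fold higher number from compound 2 to compound 3 (0.22 log units; within the scatter), toward a somewhat weaker inhibitor or none beyond the scatter. Compound 3 is estimated at 2.5 nM, with a range of 1 nM to 8 nM.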

Compound 3, half-maximal inhibitory concentration: 4.2 nM
Compound 3: the middle estimate sits 1.7-fold (0.23 log units) below what was measured, and the stated range covers the measured number.
By their numbers in this assay, from the lowest: compound 2; then compounds 3 and 1 (each within the scatter of the next).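

In this assay, among these compounds, the single change at the saturated chain carbon bound to an amine nitrogen and an aromatic carbon, 1-(4-acetamidophenyl)ethyl to 4-acetamidobenzyl, gives a 2.8-fold higher number from compound 2 to compound 3 (0.45 log units; beyond the scatter) and so provides the first single-place reading at this position: losing this one methyl moves the number by a modest step that can be told from noise. The exchange on the saturated chain carbon bound to a saturated ring carbon gives a 1.4-fold lower number from compound 1 to compound 3 (0.15 log units; within the scatter) and therefore does not separate (4-acetamidobenzyl)amino from methyl(phenylcarbamoyl)amino in this assay, even though the two groups differ far more in structure than the methyl and hydrogen of the first step. No independent data in hand bear on the reason for either step.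

As far as these compounds go, with only hydrogen and methyl compared on this carbon, it remains open whether an ethyl, a hydroxymethyl or a second methyl there would extend the step, hold it or reverse it. The compounds shown also leave open how the opposite configuration at this carbon compares with the arrangement in compound 2.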